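The source may hold more compounds than are shown below. What is called first, only, known or untested is meant among the compounds shown, and "the series" means these compounds.

Three compounds built on the shared core of compound 1 `c1ccc2c(-c3cnc4[nH]nc(-c5nc6ccccc6[nH]5)c4c3)cncc2c1` have been measured in a functional assay on HCT-116 cells (Homo sapiens) for antiproliferative activity; a higher number here means a weaker inhibitor, a lower number a stronger inhibitor. Compound 1 gives 550 nM. Compound 2 `Cc1cccc2[nH]c(-c3n[nH]c4ncc(-c5cncc6ccccc56)cc34)nc12` gives 1640 nM in this assay, and compound 3 `CC(C)NCc1cccc2[nH]c(-c3n[nH]c4ncc(-c5cncc6ccccc56)cc34)nc12` gives 110 nM. Compound 3 thus stands lowest of the three: a 5.0-fold lower number from compound 1 to compound 3 (0.70 log units; beyond the scatter) and a 15-fold lower number from compound 2 to compound 3 (1.17 log units; beyond the scatter), whereas a 3.0-fold higher number from compound 1 to compound 2 (0.47 log units; beyond the scatter).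

Compound 4 `CCN(CC)C(=O)c1cccc2[nH]c(-c3n[nH]c4ncc(-c5cncc6ccccc56)cc34)nc12` differs from compound 3 in one place: diethylcarbamoyl in place of (isopropylamino)methyl on an aromatic carbon. Going by the values given here, the steps that bear on this change are the two that lead to compound 3, because a 15-fold lower number from compound 2 to compound 3 (1.17 log units; beyond the scatter) and because a 5.0-fold lower number from compound 1 to compound 3 (0.70 log units; beyond the scatter) both point to the (isopropylamino)methyl group, with the hydrogen-bond donor it carries, as what sets compound 3 apart, and compound 4 gives up that group for one that has no hydrogen-bond donor. Among the compounds with values here, no measured step shows the diethylcarbamoyl group itself. A rise in this assay is therefore expected for compound 4, back toward the numbers of compound 1 and compound 2, with the step expected to be a 6.4-fold higher number from compound 3 to compound 4 (0.80 log units; beyond the scatter). Compound 4 is estimated to give about 700 nM, within a range from 180 nM to 2800 nM.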

Compound 4, half-maximal inhibitory concentration: 55 nM
For compound 4 the middle estimate is 13-fold (1.10 log units) above the measured one, outside the stated range (below it).
By their numbers in this assay, from the lowest: compounds 4 and 3 (each within the scatter of the next); then compound 1; then compound 2.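

In this assay this aromatic carbon accepts diethylcarbamoyl as well as (isopropylamino)methyl, with a 2.0-fold lower number from compound 3 to compound 4 (0.30 log units; within the scatter) showing that a substituent without a hydrogen-bond donor can match the amine here. The diethylcarbamoyl group also gives a 30-fold lower number from compound 2 to compound 4 (1.47 log units; beyond the scatter) and a 10-fold lower number from compound 1 to compound 4 (1.00 log units; beyond the scatter) so the advantage over methyl and hydrogen seen with compound 3 is not confined to the (isopropylamino)methyl group. No measurement available here accounts for this result.

From the compounds shown here alone, whether the amide needs both ethyl groups remains open, as a dimethylcarbamoyl group or an unsubstituted carboxamide would test this. It is equally unsettled whether a carboxylic acid or a morpholine amide at this carbon would stay in the same range as compound 3 and compound 4.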